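Benzyl for tert-butyl on the ester of compound 3

The compounds below may be only part of what the source reports. "The series", "measured", "known", "first", "only" and "open" are said of these compounds alone.

In a functional assay on NALM-6 cells (Homo sapiens) for cytotoxicity, with a stated time of 72 h (a lower number here means that less compound is needed, a higher number that more compound is needed for the effect), compound 3 (`COc1ccc(/C=C/[C@@](C)(/C=C/c2ccc(O)c(/C=C/C(=O)OC(C)(C)C)c2)CCC=C(C)C)cc1`) reads > 43400 nM as a limit, not a number. Compound 1 (`C=C[C@@](C)(/C=C/c1ccc(O)c(/C=C/C(=O)OCc2ccccc2)c1)CCC=C(C)C`), which also carries benzyloxycarbonyl, reads > 43400 nM as a limit too. Compound 2 (`COc1ccc(/C=C/[C@@](C)(/C=C/c2ccc(O)c(/C=C/C#N)c2)CCC=C(C)C)cc1`) gives 16500 nM as a true number. Among the compounds with values here, the one measured step is an at least 2.6-fold higher number from compound 2 to compound 3 (0.42 log units; beyond the scatter) and it concerns a different change. The series is bounded by the limit of > 43400 nM in this assay, at which 2 of the 3 values shown sit, and offers little to scale from.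

Compound 4 (`COc1ccc(/C=C/[C@@](C)(/C=C/c2ccc(O)c(/C=C/C(=O)OCc3ccccc3)c2)CCC=C(C)C)cc1`) has benzyl in place of tert-butyl on an oxygen next to a carbonyl group. Since compound 1 stays at > 43400 nM with the same benzyloxycarbonyl, no step beyond the scatter is expected in either direction. The expected step is an at least 1.0-fold lower number from compound 3 to compound 4 (0.03 log units; that floor lies within the scatter) and remains an estimate. The estimate for compound 4 is 40000 nM with an expected range of 15000 nM to 90000 nM and a limit rather than a number may well be expected.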

Compound 4, half-maximal effective concentration: > 43400 nM
Compound 4 gave a limit, no number (the forecaster's own chance of this, stated with the estimate: 65%); at least 1.0-fold (0.03 log units) between middle value and limit.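

Compound 4 reads > 43400 nM in this assay, a limit and not a number, so benzyl in place of tert-butyl on an oxygen next to a carbonyl group leaves this ester at the limit. Within the data shown here, with benzyloxycarbonyl in place of cyano, there is an at least 2.6-fold higher number from compound 2 to compound 4 (0.42 log units; beyond the scatter), which leaves the nitrile compound 2 as the only true number. The steps from compound 3 and from compound 1 to compound 4 cannot be read, and the series stays bounded: the limit of > 43400 nM in this assay, at which 3 of the 4 values shown sit.

Open, going by these compounds, is whether a carboxylic acid or a primary amide in place of the ester would give a true number in this assay. Also open, on these data alone, is how vinyl in place of 2-(4-methoxyphenyl)ethenyl would read alongside the nitrile.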